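Two chain stereocentres inverted: compound 3 to compound 4

The source may hold more compounds than are shown below. What is called first, only, known or untested is meant among the compounds shown, and "the series" means these compounds.

Measured so far in a functional assay on cells (Platelet, Oryctolagus cuniculus) for inhibition, read by turbidimetry, with a stated time of 5 min (a lower number here means a stronger inhibitor, a higher number a weaker inhibitor), as follows:
compound 1 `CCCC[C@@H]1NC(=O)c2ccccc21` - 700000 nM
compound 2 `CCCC[C@H](OC(=O)CN(C)C)c1ccccc1C(=O)O[C@H]1CO[C@H]2[C@@H]1OC[C@H]2OC(=O)c1ccccc1[C@H](CCCC)OC(=O)CN(C)C` - 310000 nM
compound 3 `CCCC[C@@H](OC(=O)CN1CCCC1)c1ccccc1C(=O)O[C@H]1CO[C@H]2[C@@H]1OC[C@H]2OC(=O)c1ccccc1[C@@H](CCCC)OC(=O)CN1CCCC1` - 1000000 nM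

Compound 3 stands at 1000000 nM in this assay and lies within the scatter of compound 1, while its number is higher, beyond the scatter, than that of compound 2, which reads 310000 nM on this scale. The step to compound 4 `CCCC[C@H](OC(=O)CN1CCCC1)c1ccccc1C(=O)O[C@H]1CO[C@H]2[C@@H]1OC[C@H]2OC(=O)c1ccccc1[C@H](CCCC)OC(=O)CN1CCCC1` is the two compounds have the same atoms and bonds and differ only in configuration as drawn: 2 of 6 stereo elements differ; a stereocentre at a saturated chain carbon is drawn R in compound 3 and S in compound 4; a stereocentre at a saturated chain carbon is drawn R in compound 3 and S in compound 4 in the drawn structures. The two compounds have the same atoms and bonds, and two stereocentres at saturated chain carbons are drawn R in compound 3 and S in compound 4.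

Going by the values given here, no pair of measured compounds isolates such a change, so the data show no size for it. The measured numbers lie close together, from compound 2 at 310000 nM to compound 3 at 1000000 nM in this assay, so the expected step is small, towards a lower number, and not beyond the scatter. A step of a 1.7-fold lower number from compound 3 to compound 4 (0.22 log units; within the scatter) is expected on this reading. For compound 4 the estimated value is 600000 nM with an expected range from 200000 nM to 1500000 nM as the likely span.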

Compound 4, half-maximal inhibitory concentration: 800000 nM
Estimate against measurement, compound 4: 1.3-fold (0.12 log units) below; the range from low to high includes it.
By their numbers in this assay, from the lowest: compound 2; then compounds 1, 4 and 3 (each within the scatter of the next).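

Inverting the two stereocentres at saturated chain carbons gives a 1.3-fold lower number from compound 3 to compound 4 (0.10 log units; within the scatter) in this assay, and this is the first size the set offers for any single change, since no earlier pair of compounds differed in one place only. In this pair, the drawn configuration at these two carbons therefore moves the number by no more than the assay's ordinary scatter, with compound 3 at 1000000 nM and compound 4 at 800000 nM, both high on a scale where a higher number means a weaker inhibitor. The reading is a clean one for configuration, as nothing else separates the two structures: the fact that compounds 3 and 4 differ only in the configuration as drawn

The compounds shown leave open how a form with only one of the two chain stereocentres inverted would read, since both centres change together in this pair. They also leave open whether the same inversion would stay within the scatter with a longer chain at those carbons, or with a primary amine or a carboxylic acid at the end of the ester arms.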